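Swapping one small ring on a carbonyl carbon

This account rests on a few compounds, and the source may have more. Where it says the series, first, only, none or still open, it means among the compounds named here.

Measured in an ADME assay on microsomes from liver (Homo sapiens) for pharmacokinetics; a lower number here means slower removal, a higher number faster removal of the compound:
- compound 1 `Cn1cc(-c2ncc(C#N)c(N3C[C@@H]4C[C@H]3CN4CC3CC3)n2)cn1`: < 16 mL/min/kg
- compound 2 `C[C@@H]1C[C@H]1C(=O)N1CCN(c2nc(-c3cnn(C)c3)ncc2C#N)C[C@H]1C`: < 16 mL/min/kg
- compound 3 `C[C@@H]1CN(c2nc(-c3cnn(C)c3)ncc2C#N)CCN1C(=O)C1(C)CC1`: < 16 mL/min/kg

None of these three results is an exact number. Each one is a limit of the assay, and together they make up (the limit of < 16 mL/min/kg in this assay, at which 3 of the 3 values shown sit). Compound 3 therefore stands at the same limit as the other two, and no order among them can be read.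

The next compound is compound 4 `C[C@@H]1CN(c2nc(-c3cnn(C)c3)ncc2C#N)CCN1C(=O)C1CCC1`. It carries cyclobutyl in place of 1-methylcyclopropyl on a carbonyl carbon, and the two compounds have the same atoms, joined differently: cyclobutyl in place of 1-methylcyclopropyl on a carbonyl carbon.

Going by the values given here, only one measured step bears on this change, because it falls on a carbonyl carbon too: a step that the two limits leave unreadable from compound 2 to compound 3. Both ends of that step are limits, so it offers no size to carry over. The expectation rests mainly on compound 3, whose < 16 mL/min/kg is a limit. No step beyond the usual scatter is expected in this assay, and no direction is favoured. The expected change, a step that the limit leaves unreadable from compound 3 to compound 4, is an estimate only. For compound 4 the estimated clearance is 15 mL/min/kg, with an expected range from 9 mL/min/kg to 30 mL/min/kg.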

Compound 4, clearance: < 16 mL/min/kg
Compound 4 was reported as a limit; the forecaster's own chance of this, stated with the estimate: 60%; the middle value is on the limit's open side.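

In this assay compound 4 gives < 16 mL/min/kg as a limit of the assay. No step to compound 4 can be read from compound 2 or compound 3, because all the results sit at one limit: the limit of < 16 mL/min/kg in this assay, at which 4 of the 4 values shown sit.

On these data alone, how far these compounds truly differ in clearance, and whether the ring on the carbonyl carbon matters for it, stays open.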